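Swapping the Chloromethyl Group of a Strong Inhibitor

The compounds below may be only part of what the source reports. "The series", "measured", "known", "first", "only" and "open" are said of these compounds alone.

Measured in a functional assay on MGC-803 cells (Homo sapiens) for inhibition, read by MTT assay, with a stated time of 48 h; a lower number here means a stronger inhibitor, a higher number a weaker inhibitor:
- compound 1 `C/C=C/C(=O)N(Cc1ccc(OC)c(C)c1)c1cc(OC)c(OC)c(OC)c1`: 14500 nM
- compound 2 `COc1ccc(CN(C(=O)CCl)c2cc(OC)c(OC)c(OC)c2)cc1O`: 84 nM

Compound 2, at 84 nM, has the lower of the two numbers, and the gap to compound 1 lies well beyond the scatter. Compound 3 `C/C=C/C(=O)N(Cc1ccc(OC)c(O)c1)c1cc(OC)c(OC)c(OC)c1` puts prop-1-en-1-yl in place of chloromethyl on a carbonyl carbon. For the measured compounds named here, no measured pair shows this change alone. However, compound 1 carries the same prop-1-en-1-yl and gives 14500 nM, which points to a weaker inhibitor. The expected change is a 30-fold higher number from compound 2 to compound 3 (1.47 log units; beyond the scatter), a rise beyond the scatter. Compound 3 is estimated at 2500 nM, with an expected range of 400 nM to 14000 nM.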

Compound 3, half-maximal inhibitory concentration: 27 nM
Estimate against measurement, compound 3: 93-fold (1.97 log units) above; the whole stated range lies above it.
By their numbers in this assay, from the lowest: compound 3; then compound 2; then compound 1.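

In this assay, prop-1-en-1-yl on this carbonyl carbon does not cost strength when the aromatic hydroxy is present: replacing chloromethyl gives a 3.1-fold lower number from compound 2 to compound 3 (0.49 log units; beyond the scatter). The weak result for compound 1 therefore does not carry over to every compound with prop-1-en-1-yl, as hydroxy in place of methyl on an aromatic carbon gives a 540-fold lower number from compound 1 to compound 3 (2.73 log units; beyond the scatter). No evidence on the cause of either step is at hand.

Still open, from the compounds shown here alone, is how an ethyl group or an amine on this carbonyl carbon would compare. Going by these compounds, whether chloromethyl depends equally on the aromatic hydroxy also remains unknown.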